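Amino substitution on the benzylamine series of KYSE-450 inhibitors

The compounds below may be only part of what the source reports. "The series", "measured", "known", "first", "only" and "open" are said of these compounds alone.

Compound 2 `C/C=C/C(=O)N(Cc1ccc(OC)cc1)c1cc(OC)c(OC)c(OC)c1` serves as the reference. In a functional assay on KYSE-450 cells (Homo sapiens) for inhibition, read by MTT assay, with a stated time of 48 h (on this read-out higher numbers stand for weaker inhibition and lower numbers for stronger inhibition), compound 2 gives 420 nM. Compound 1 `C/C=C/C(=O)N(Cc1ccc(OC)c(N)c1)c1cc(OC)c(OC)c(OC)c1` differs from it by amino in place of hydrogen on an aromatic carbon and in this assay compound 1 gives 310 nM, a step of a 1.4-fold lower number from compound 2 to compound 1 (0.13 log units; within the scatter). Compound 3 `COc1ccc(CNc2cc(OC)c(OC)c(OC)c2)cc1` differs from compound 2 by hydrogen in place of (prop-1-en-1-yl)carbonyl on a nitrogen on an aromatic ring; in this assay compound 3 gives 4890 nM, a step of a 12-fold higher number from compound 2 to compound 3 (1.07 log units; beyond the scatter). Compound 4 `COc1ccc(CNc2cc(OC)c(OC)c(OC)c2)cc1N` is not yet measured; it differs from compound 3 by amino in place of hydrogen on an aromatic carbon, the same change as that from compound 2 to compound 1, on the core of compound 3 rather than of compound 2. Since the earlier step was a 1.4-fold lower number from compound 2 to compound 1 (0.13 log units; within the scatter), the expected step from compound 3 to compound 4 is a 1.4-fold lower number from compound 3 to compound 4 (0.15 log units; within the scatter), also within the scatter. Compound 4 is therefore estimated at 3500 nM, between 1500 nM and 9000 nM.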

Compound 4, half-maximal inhibitory concentration: 2210 nM
Beside the measured number, compound 4's estimate is 1.6-fold (0.20 log units) above it; the measured number falls inside the stated range.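

In this assay, amino in place of hydrogen on an aromatic carbon gives a 2.2-fold lower number from compound 3 to compound 4 (0.34 log units; beyond the scatter), and the size of this change does not differ measurably between the two cores: the same change on two cores in this assay, a 1.4-fold lower number (0.13 log units; within the scatter) from compound 2 to compound 1 and a 2.2-fold lower number (0.34 log units; beyond the scatter) from compound 3 to compound 4, 1.6-fold (0.21 log units) apart, within the scatter of two such steps. Hydrogen in place of (prop-1-en-1-yl)carbonyl on the nitrogen also carries over, giving a 7.1-fold higher number from compound 1 to compound 4 (0.85 log units; beyond the scatter): the same change on two cores in this assay, a 12-fold higher number (1.07 log units; beyond the scatter) from compound 2 to compound 3 and a 7.1-fold higher number (0.85 log units; beyond the scatter) from compound 1 to compound 4, 1.6-fold (0.21 log units) apart, within the scatter of two such steps. Both changes therefore transfer within these four compounds, but this does not show that they would transfer to any other core, and the amino step lies within the scatter on one core and beyond it on the other, so its true size remains unsettled.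

On these data alone, whether hydroxy or methyl on that aromatic carbon would behave like amino remains open. Also open, as far as these compounds go, is whether an acetyl group or a longer acyl chain on the nitrogen would match (prop-1-en-1-yl)carbonyl.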